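Thiophene Amide Replacing Butanamide on a Shared Azole Core

The source may hold more compounds than are shown below. What is called first, only, known or untested is meant among the compounds shown, and "the series" means these compounds.

Compound 1 `CCCC(=O)Nc1ccc(N2CCN(c3ccc(OC[C@@H]4CO[C@@](Cn5cncn5)(c5ccc(Cl)cc5Cl)O4)cc3)CC2)cc1`: 9930 nM
Compound 2 `O=C(Nc1ccc(N2CCN(c3ccc(OC[C@@H]4CO[C@@](Cn5cncn5)(c5ccc(Cl)cc5Cl)O4)cc3)CC2)cc1)c1cccc(F)c1`: 10800 nM

In a functional assay on HepG2 cells (Homo sapiens) for inhibition, read by MTT assay, with a stated time of 48 h (a higher number here means a weaker inhibitor, a lower number a stronger inhibitor), compound 1 stands at 9930 nM, and compound 2 stands at 10800 nM, the two numbers lying within the scatter of each other. For the measured compounds named here, the single measured step, a 1.1-fold higher number from compound 1 to compound 2 (0.04 log units; within the scatter), exchanged the propyl on the carbonyl carbon for 3-fluorophenyl without moving the reading beyond the scatter.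

Compound 3 `O=C(Nc1ccc(N2CCN(c3ccc(OC[C@@H]4CO[C@@](Cn5cncn5)(c5ccc(Cl)cc5Cl)O4)cc3)CC2)cc1)c1cccs1` has not yet been measured. It differs from compound 1 in one place: thiophen-2-yl in place of propyl on a carbonyl carbon. Going by the values given here, the only step that bears on this change is a 1.1-fold higher number from compound 1 to compound 2 (0.04 log units; within the scatter), which likewise replaced the propyl on the same carbonyl carbon with a ring and gave no step beyond the scatter. On that basis the step is expected to be a 1.1-fold higher number from compound 1 to compound 3 (0.02 log units; within the scatter), within the scatter. Compound 3 is therefore estimated at 10500 nM in this assay, with a range from 5000 nM to 22000 nM.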

Compound 3, half-maximal inhibitory concentration: 9770 nM
Beside the measured number, compound 3's estimate is 1.1-fold (0.03 log units) above it; low and high end bracket the measured number.
By their numbers in this assay, from the lowest: compounds 3, 1 and 2 (each within the scatter of the next).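

Thiophen-2-yl on the carbonyl carbon gives the step of a 1.0-fold lower number from compound 1 to compound 3 (0.01 log units; within the scatter) in this assay, so a second ring, this time a five-membered aromatic ring with a sulfur atom, also leaves the reading within the scatter of the propyl compound. The exchange of one ring for the other, a 1.1-fold lower number from compound 2 to compound 3 (0.04 log units; within the scatter) in the same assay, shows that the swap from 3-fluorophenyl to thiophen-2-yl makes no readable difference either, so all three groups on this carbonyl carbon read alike. Nothing available explains this sameness.

Going by these compounds, it remains open whether an amine, a carboxylic acid or a longer chain on this carbonyl carbon would move the number beyond the scatter. The compounds shown also leave open whether the amide itself matters, since each of them carries it.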